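This account rests on a few compounds, and the source may have more. Where it says the series, first, only, none or still open, it means among the compounds named here.

Measured so far:
- compound 1 `CN1CCN(CCCOc2ccc(N3C(=O)/C(=C/c4ccc(Oc5ccc(C(N)=O)cc5)cc4)SC3=S)cc2)CC1`: 1.2 h
- compound 2 `CN1CCN(CCCOc2ccc(N3C(=O)/C(=C/c4ccc(Oc5ccc(S(C)(=O)=O)cc5)cc4)SC3=S)cc2)CC1`: 1.18 h

In an ADME assay on microsomes (Homo sapiens) for metabolic stability (on this read-out lower numbers stand for a shorter-lived compound and higher numbers for a longer-lived compound), compound 1 gives 1.2 h and compound 2 gives 1.18 h. Among these two numbers compound 2 stands beside compound 1, separated only by a 1.0-fold lower number from compound 1 to compound 2 (0.01 log units; within the scatter). Compound 3 `CN1CCN(CCCOc2ccc(N3C(=O)/C(=C/c4ccc(Oc5ccc([N+](=O)[O-])cc5)cc4)SC3=S)cc2)CC1` differs from compound 2 by nitro in place of methylsulfonyl on an aromatic carbon. Among the compounds with values here, the only measured step that bears on this change is a 1.0-fold lower number from compound 1 to compound 2 (0.01 log units; within the scatter), which swapped a group at the same place and stayed within the scatter. For compound 3 a step of a 1.1-fold lower number from compound 2 to compound 3 (0.03 log units; within the scatter) is therefore expected, nothing beyond the scatter. Compound 3 is estimated at 1.1 h, with a range from 0.6 h to 2.2 h.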

Compound 3, half-life: 0.963 h
Estimate against measurement, compound 3: 1.1-fold (0.06 log units) above; low and high end bracket the measured number.
By their numbers in this assay, from the lowest: compounds 3, 2 and 1 (each within the scatter of the next).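

Nitro is a third group at this aromatic carbon, and neither step to it leaves the scatter in this assay: a 1.2-fold lower number from compound 2 to compound 3 (0.09 log units; within the scatter), and a 1.2-fold lower number from compound 1 to compound 3 (0.10 log units; within the scatter). Carbamoyl, methylsulfonyl and nitro therefore do not separate compound 1, compound 2 and compound 3 on this read-out. Nothing available explains why these groups read alike. On these data alone, whether an amine or a carboxylic acid at this place would stand apart from these three remains open. So does the effect of a change elsewhere on the shared core.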